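From Chloro to Fluoro on an Aromatic Carbon

The source may hold more compounds than are shown below. What is called first, only, known or untested is meant among the compounds shown, and "the series" means these compounds.

Compound 1 (`Cc1cc(Cl)cc(Cl)c1S(=O)(=O)N1CCC(N2CCC(C)CC2)CC1`) gives > 5000 nM as a limit
Compound 2 (`CC1CCN(C2CCN(S(=O)(=O)c3cccnc3Cl)CC2)CC1`) gives > 10000 nM as a limit
Compound 3 (`Cc1cc(C)c(S(=O)(=O)N2CCC(N3CCC(CCO)CC3)CC2)c(C)c1`) gives > 5000 nM as a limit

All three values come from an ADME assay on HCT-116 cells (Homo sapiens) for cytotoxicity, read by CellTiter-Glo, with a stated time of 72 h (on this read-out higher numbers stand for weaker inhibition and lower numbers for stronger inhibition), and each is a limit of the assay rather than a number. Compound 2 stands at the limit of > 10000 nM in this assay, at which 1 of the 3 values shown sits, and has no number of its own. Compound 1 and compound 3 stand at the limit of > 5000 nM in this assay, at which 2 of the 3 values shown sit, and likewise have no number. Among the measured compounds shown here, no order among the three can be read from these limits, and no two of them differ in one place only, so no measured step is available as a guide.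

Compound 4 (`CC1CCN(C2CCN(S(=O)(=O)c3cccnc3F)CC2)CC1`) has not yet been measured. Its difference from compound 2 is fluoro in place of chloro on an aromatic carbon and is fluoro in place of chloro on an aromatic carbon, next to the ring nitrogen and ortho to a large group.

In this assay no step beyond the scatter is expected for this exchange. For the measured compounds named here, that expectation rests on compound 2 with its limit of > 10000 nM as the only close neighbour. The estimate is a step that the limit leaves unreadable from compound 2 to compound 4 and it is expected to stay within the scatter. Compound 4 is estimated at 12000 nM with an expected range from 6000 nM to 25000 nM in this read-out.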

Compound 4, half-maximal inhibitory concentration: > 10000 nM
Compound 4 ended at the assay's limit; the forecaster's own chance of this, stated with the estimate: 85%; the middle value lies beyond the limit too.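

In this assay compound 4 gives > 10000 nM, a limit of the assay and not a number. Among the compounds shown here, compound 2 gives > 10000 nM, also a limit, and no step between compound 2 and compound 4 can be read. The compounds shown leave open whether fluoro and chloro at this place differ at all in this assay.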